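Swapping a nitrophenyl for thiophene on a weakly active core

This account rests on a few compounds, and the source may have more. Where it says the series, first, only, none or still open, it means among the compounds named here.

Of the compounds shown here, three sharing one core have been tested in a functional assay on Ehrlich cells (Mus musculus) for cytotoxicity; on this read-out higher numbers stand for weaker inhibition and lower numbers for stronger inhibition. Compound 1 `COc1cc(N2C(N)=C(C#N)C(c3ccc([N+](=O)[O-])cc3)C3=C2CC(C)(C)CC3=O)cc(OC)c1OC` gives 25000 nM. Compound 2 `COc1cc(N2C(N)=C(C#N)C(/C=C/c3ccccc3)C3=C2CC(C)(C)CC3=O)cc(OC)c1OC` gives "not active" (no number reported), a qualitative outcome without a number. Compound 3 `COc1cc(N2C(N)=C(C#N)C(c3cccc([N+](=O)[O-])c3)C3=C2CC(C)(C)CC3=O)cc(OC)c1OC` likewise gives "not active" (no number reported), so its standing cannot be placed on a numerical scale; it simply did not show measurable inhibition, as with compound 2. Compound 4 `COc1cc(N2C(N)=C(C#N)C(c3cccs3)C3=C2CC(C)(C)CC3=O)cc(OC)c1OC` has not been tested yet. It differs from compound 3 in one place: thiophen-2-yl in place of 3-nitrophenyl on a saturated ring carbon. With no numerical value for compound 3 and only compound 1 offering a weak number, no direction for this step can be read off, and any activity is expected to remain weak. Compound 4 is expected to give roughly 40000 nM, within a range from 15000 nM to 150000 nM.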

Compound 4, half-maximal inhibitory concentration: "not active" (no number reported)
For compound 4 the study gives words and no number; no gap can be computed for the estimate.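

Within the data shown here, compound 3 and compound 4 are both reported only as not active in this assay, so no step between them can be read. The compounds shown leave open whether 3-nitrophenyl and thiophen-2-yl differ at all in inhibition. No available evidence bears on this result.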